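From Cyclopentyl to (Oxan-4-yl)methyl on an Aromatic Nitrogen

The source may report more compounds than this note shows. Statements on the series, on what has been measured and on what is new or still open speak of the compounds shown alone.

In a functional assay on HT-29 cells (Homo sapiens) for inhibition, read by luminescence and CellTiter-Glo, with a stated time of 24 h (a higher number here means that more compound is needed for the effect, a lower number that less compound is needed), compound 3 `CN1C(=S)[C@@H](NC(=O)c2nc(Cc3ccccc3)n(C3CCCC3)n2)COc2ccccc21` gives 3530 nM, which lies within the scatter of compound 1 `CC(C)CCn1nc(C(=O)N[C@H]2COc3ccccc3N(C)C2=S)nc1Cc1ccccc1` at 3640 nM and of compound 2 `CN1C(=S)[C@@H](NC(=O)c2nc(Cc3ccccc3)n(CCCC#N)n2)COc2ccccc21` at 2400 nM. Compound 4 `CN1C(=S)[C@@H](NC(=O)c2nc(Cc3ccccc3)n(CC3CCOCC3)n2)COc2ccccc21` carries (oxan-4-yl)methyl in place of cyclopentyl on an aromatic nitrogen. Three measured steps change the group on that nitrogen: a 1.5-fold lower number from compound 1 to compound 2 (0.18 log units; within the scatter), a 1.0-fold lower number from compound 1 to compound 3 (0.01 log units; within the scatter) and a 1.5-fold higher number from compound 2 to compound 3 (0.17 log units; within the scatter). All three stay within the scatter. None of these compounds has the oxan-4-yl ring in that group, so its effect remains untested. No step beyond the scatter is therefore expected in this assay, and the estimated step is a 1.2-fold lower number from compound 3 to compound 4 (0.07 log units; within the scatter). For compound 4 the estimated value is 3000 nM, with an expected range of 1500 nM to 6500 nM.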

Compound 4, half-maximal effective concentration: 6310 nM
Compound 4: the middle estimate sits 2.1-fold (0.32 log units) below what was measured, and the stated range covers the measured number.
By their numbers in this assay, from the lowest: compounds 2, 3, 1 and 4 (each within the scatter of the next, the first and the last beyond it).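

In this assay the group on this aromatic nitrogen now gives a step beyond the scatter, though a modest one: a 2.6-fold higher number from compound 2 to compound 4 (0.42 log units; beyond the scatter) for (oxan-4-yl)methyl against 3-cyanopropyl. The other two changes stay within the scatter, with a 1.8-fold higher number from compound 3 to compound 4 (0.25 log units; within the scatter) and a 1.7-fold higher number from compound 1 to compound 4 (0.24 log units; within the scatter) on the same nitrogen, so only one pair among these compounds separates clearly. Nothing available explains that step.

A cyclohexylmethyl group, with carbon in place of the ring oxygen, would show whether that oxygen counts. A (piperidin-4-yl)methyl group would put an amine there instead.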